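This account rests on a few compounds, and the source may have more. Where it says the series, first, only, none or still open, it means among the compounds named here.

Measured in an ADME assay on a cell-free system (plasma, Homo sapiens) for metabolic stability, read by LC-MS, tested at 10 ug/mL; on this read-out lower numbers stand for a shorter-lived compound and higher numbers for a longer-lived compound:
Compound 1, `COC(=O)c1cc(N)c(Nc2ccc(C#N)cc2)cc1Oc1c(C)cc(/C=C/C#N)cc1C`: 89 h
Compound 2, `Cc1cc(/C=C/C#N)cc(C)c1Oc1cc(Nc2ccc(C#N)cc2)c(N)cc1C(=O)NN`: 8 h
Compound 3, `Cc1cc(/C=C/C#N)cc(C)c1Oc1cc(Nc2ccc(C#N)cc2)c(N)cc1C(N)=O`: 65 h

Compound 3 stands second highest of the three numbers in this assay; its nearest neighbour is compound 1, a 1.4-fold lower number from compound 1 to compound 3 (0.14 log units; within the scatter), a gap within the scatter, while compound 2 lies furthest off, an 8.1-fold higher number from compound 2 to compound 3 (0.91 log units; beyond the scatter).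

Compound 4, `CNC(=O)c1cc(N)c(Nc2ccc(C#N)cc2)cc1Oc1c(C)cc(/C=C/C#N)cc1C`, differs from compound 3 by methyl in place of hydrogen on an amide-type nitrogen. The step that bears most directly on it is the other change on this amide-type nitrogen, an 8.1-fold higher number from compound 2 to compound 3 (0.91 log units; beyond the scatter), which was large, whereas the change at the carbonyl carbon, a 1.4-fold lower number from compound 1 to compound 3 (0.14 log units; within the scatter), stayed within the scatter. A substituent on the amide-type nitrogen therefore seems able to move the number, and the direction for a methyl is uncertain.

Compound 4 is expected to give about 45 h in this assay, within 12 h to 130 h, an estimated step of a 1.4-fold lower number from compound 3 to compound 4 (0.16 log units; within the scatter).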

Compound 4, half-life: 72 h
For compound 4 the middle estimate is 1.6-fold (0.20 log units) below the measured one, within the range that was stated.
By their numbers in this assay, from the lowest: compound 2; then compounds 3, 4 and 1 (each within the scatter of the next).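

In this assay a methyl on the amide-type nitrogen stays within the scatter of hydrogen, a 1.1-fold higher number from compound 3 to compound 4 (0.04 log units; within the scatter), whereas the amino group of compound 2 remains the one substituent here that stands apart, a 9.0-fold higher number from compound 2 to compound 4 (0.95 log units; beyond the scatter). Methylamino in place of methoxy on the carbonyl carbon also stays within the scatter, a 1.2-fold lower number from compound 1 to compound 4 (0.09 log units; within the scatter). No measurement shown here explains these results. The compounds shown leave open whether an ethyl group or a second methyl on this nitrogen would give a similar number.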